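Oxolane attachment point in the aryl ether series

The compounds below may be only part of what the source reports. "The series", "measured", "known", "first", "only" and "open" are said of these compounds alone.

Compound 1 `CC(C)Oc1cccc2ccc(N)nc12` gives 437 nM in an assay on cells with melanin-concentrating hormone receptor 1 (Homo sapiens) as the target, read by radioligand binding; on this read-out lower numbers stand for stronger inhibition and higher numbers for weaker inhibition. Compound 2 `CCCC(C)Oc1cccc2ccc(N)nc12` gives 105 nM in this assay. Compound 3 `Nc1ccc2cccc(OCC3CCCO3)c2n1` gives > 2000 nM in this assay, and this is a limit of the assay, not a number.

Compound 3 thus stands at the limit of > 2000 nM in this assay, at which 1 of the 3 values shown sits, the weakest end of what was measured. Compound 4 `Nc1ccc2cccc(OCC3CCOC3)c2n1` differs from it by oxolan-3-yl in place of oxolan-2-yl on a saturated chain carbon bound to an oxygen on an aromatic ring. Among the compounds with values here, the steps that bear on this are an at least 4.5-fold higher number from compound 1 to compound 3 (0.66 log units; beyond the scatter) and an at least 19-fold higher number from compound 2 to compound 3 (1.27 log units; beyond the scatter), both showing the oxolan-2-ylmethyl ether far weaker than the open-chain ethers. Within the data shown here, no measured step moves the attachment point of the ring, so no clear push in either direction is expected, and a step that the limit leaves unreadable from compound 3 to compound 4 is expected to stay within the scatter. Compound 4 is estimated at 3500 nM, within 1000 nM to 12000 nM.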

Compound 4, half-maximal inhibitory concentration: 115 nM
Compound 4: middle estimate off by 30-fold (1.48 log units), on the high side, outside the stated range (below it).
By their numbers in this assay, from the lowest: compounds 2 and 4 (each within the scatter of the next); then compound 1. At a limit, above all of these: compound 3.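

At this ether, the attachment point of the oxolane ring decides the read-out, and oxolan-3-yl in place of oxolan-2-yl gives an at least 17-fold lower number from compound 3 to compound 4 (1.24 log units; beyond the scatter). That step is only a bound, since compound 3 stands at a limit of the assay and not at a number: the limit of > 2000 nM in this assay, at which 1 of the 4 values shown sits. The ring itself therefore carries no general penalty, as (oxolan-3-yl)methyl shows a 1.1-fold higher number from compound 2 to compound 4 (0.04 log units; within the scatter) and a 3.8-fold lower number from compound 1 to compound 4 (0.58 log units; beyond the scatter).

Still open, as far as these compounds go, is whether the ring oxygen matters at all, which a cyclopentylmethyl ether would test. An amine in place of that ring oxygen would extend the same question.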